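The compounds below may be only part of what the source reports. "The series", "measured", "known", "first", "only" and "open" are said of these compounds alone.

Compound 1 `COc1ccc(-n2nncc2CN2C(=O)C3(C(C#N)=C(N)Oc4c3c3nc5ccccc5nc3c3ccccc43)c3ccccc32)cc1` and compound 2 `N#CC1=C(N)Oc2c(c3nc4ccccc4nc3c3ccccc23)C12C(=O)N(Cc1cnnn1-c1ccc(S(N)(=O)=O)cc1)c1ccccc12` share one core and differ in a single group on an aromatic carbon. In an ADME assay on L02 cells (Homo sapiens) for antiproliferative activity, read by MTT assay, with a stated time of 48 h (a lower number here means a stronger inhibitor, a higher number a weaker inhibitor), compound 1 gives > 50000 nM, which is a limit of the assay and not a number. In this assay compound 2 gives > 50000 nM, likewise a limit of the assay rather than a number. Within the data shown here, the only measured step, a step that the two limits leave unreadable from compound 1 to compound 2, therefore cannot be read, since the limit of > 50000 nM in this assay, at which 2 of the 2 values shown sit, shows where both values sit. Compound 3 `N#CC1=C(N)Oc2c(c3nc4ccccc4nc3c3ccccc23)C12C(=O)N(Cc1cnnn1-c1ccc(F)c(Cl)c1)c1ccccc12` is not yet measured; it differs from compound 2 by 3-chloro-4-fluorophenyl in place of 4-sulfamoylphenyl on an aromatic nitrogen. Among the measured compounds shown here, no measured step bears on this change, and the two values so far place compound 2 only at the limit. The step that the limit leaves unreadable from compound 2 to compound 3 that the estimate below means is expected to be none beyond the scatter. Compound 3 is estimated at 60000 nM in this assay, within the range 30000 nM to 150000 nM, most likely again reported only as a limit.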

Compound 3, half-maximal inhibitory concentration: > 50000 nM
Compound 3 gave a limit, no number (the forecaster's own chance of this, stated with the estimate: 80%); the middle value does not contradict the limit.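

No step from compound 1 or compound 2 to compound 3 can be read, because each value is a limit of this assay and not a number: the limit of > 50000 nM in this assay, at which 3 of the 3 values shown sit.

The compounds shown leave open how 4-methoxyphenyl, 4-sulfamoylphenyl and 3-chloro-4-fluorophenyl on the shared core truly compare in this assay.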